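A few compounds are considered here, and "the series" means these few. Any claim that something is new, unique, unknown or untested is made for them only; others in the source may bear on it.

Measured compounds:
- compound 1 `O[C@H]1CO[C@H](COCc2ccccc2)[C@@H](OCc2ccccc2)[C@@H]1OCc1ccccc1` — "not active" (no number reported) in a functional assay on HL-60 cells (Homo sapiens) for antiproliferative activity, read by MTT assay; on this read-out lower numbers stand for stronger inhibition and higher numbers for weaker inhibition
- compound 2 `CCCC[C@H]1O[C@H](COCc2ccccc2)[C@@H](OCc2ccccc2)[C@H](OCc2ccccc2)[C@H]1O` — "not active" (no number reported)
- compound 3 `c1ccc(COC[C@H]2OCC[C@@H](OCc3ccccc3)[C@@H]2OCc2ccccc2)cc1` — 39300 nM

Compound 1 carries no single number in this assay; one further entry, compound 2, likewise reports no number, so compound 1 cannot be ranked against the others. Only compound 3 gives a numerical value, and it is a weak one.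

Compound 4 `O[C@@H]1[C@@H](OCc2ccccc2)[C@H](OCc2ccccc2)[C@@H](COCc2ccccc2)O[C@H]1CC1CC1` differs from compound 1 by cyclopropylmethyl in place of hydrogen on a saturated ring carbon. For the measured compounds named here, no measured pair shows this change, so the size of the step is unknown. Compound 2, which carries a four-carbon chain on the same core, is also without number, which argues against any move toward stronger inhibition beyond the scatter. Compound 4 is therefore expected to remain weak, estimated at 50000 nM with a range of 15000 nM to 200000 nM, and a report of no number is considered likely.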

Compound 4, half-maximal inhibitory concentration: "not active" (no number reported)
The entry for compound 4 holds no number; there is nothing to compare the estimate with.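

In this assay compound 1 and compound 4 both carry no number, so no step can be read between them. No evidence bears on this result. As far as these compounds go, whether cyclopropylmethyl on the shared core shifts inhibition at all remains open.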